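From Ethyl to Acetamido in a Small Series

This account rests on a few compounds, and the source may have more. Where it says the series, first, only, none or still open, it means among the compounds named here.

- Compound 1 `NC(=S)N/N=C(/COc1ccc(Br)cc1)c1ccccc1` gives < 27500 nM as a limit
- Compound 2 `NC(=S)N/N=C(/COc1ccc(Br)cc1)c1ccc(Br)cc1` gives 22600 nM as a number
- Compound 3 `CCc1ccc(OC/C(=N\NC(N)=S)c2ccc(Br)cc2)cc1` gives < 25500 nM as a limit

All three compounds were tested in an ADME assay on L929 cells (Mus musculus) for cytotoxicity, read by resazurin assay, with a stated time of 96 h (on this read-out lower numbers stand for higher toxicity in this test and higher numbers for lower toxicity in this test), and these are their only results. Compound 3 stands at < 25500 nM and this is a limit, not a number. Compound 1 also has only a limit, < 27500 nM in this case. Compound 2 is therefore the only one of the three with a number.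

The next compound is compound 4 `CC(=O)Nc1ccc(OC/C(=N\NC(N)=S)c2ccc(Br)cc2)cc1` which carries acetamido in place of ethyl on an aromatic carbon, para to a large group (acetamido in place of ethyl on an aromatic carbon). Within the data shown here, the one measured step is a step that the limit leaves unreadable from compound 1 to compound 2 and it concerns a different change, so it offers no size to carry over. Among the measured compounds shown here, no measured step replaces ethyl or introduces acetamido.

With so little to go on, no step beyond the usual scatter is expected. For the measured compounds named here, compound 2 with 22600 nM is the only number available as an anchor. By this estimate the expected change is a step that the limit leaves unreadable from compound 3 to compound 4 in the read-out. Compound 4 could also be reported only as a limit. Compound 4 is estimated at 23000 nM in this assay with an expected range from 8000 nM to 70000 nM for its measurement.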

Compound 4, half-maximal cytotoxic concentration: 94900 nM
Compound 4: the middle estimate sits 4.1-fold (0.62 log units) below what was measured, and the stated range ends below it.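

In this assay, acetamido in place of ethyl on an aromatic carbon, para to a large group, gives an at least 3.7-fold higher number from compound 3 to compound 4 (0.57 log units; beyond the scatter), and on this read-out the higher number stands for lower toxicity in this test. Among these compounds, this is the first readable step and the first evidence that the read-out responds to a change at this position, since the earlier step concerned a different change and cannot be read. The true size of the step remains open because compound 3 is known only through a limit: the limit of < 25500 nM in this assay, at which 1 of the 4 values shown sits.

The compounds shown do not separate the contributions of the amide hydrogen, the carbonyl and the larger group as a whole, and a simple amine or a carboxylic acid on the same aromatic carbon would help to tell these apart. They also leave open whether a longer chain in place of ethyl would move the read-out, and whether the same change would give a similar step in a compound with a different partner elsewhere on the shared core.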